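The compounds below may be only part of what the source reports. "The series", "measured", "known", "first", "only" and "open" are said of these compounds alone.

Three compounds of a shared core have been examined for antagonism in an in vitro functional assay on B300-19 cells for antagonist activity at C-C chemokine receptor type 4 (Homo sapiens), read by GTPgammaS binding, tested at 1 uM; a lower number here means less inhibition, a higher number more inhibition at the concentration tested (going by the name of the read-out). Compound 1 `COc1cc2nc(NCc3ccccc3)nc(NC3CCCCCC3)c2cc1OC` carries a benzylamino group and a cycloheptylamino group on the core, and in this assay compound 1 gives 13%. Compound 2 `COc1cc2nc(N3CCC(N4CCCC4)CC3)nc(N3CCCCC3)c2cc1OC` gives 8% in this assay, and compound 3 `c1ccc2c(NC3CCCCCC3)nc(N3CCC(N4CCCC4)CC3)nc2c1` gives 10%. Compound 1 stands at the top of these three numbers, but the gap to compound 3 and the gap to compound 2 both lie within the usual scatter of such measurements, so the three readings cannot be told apart; all of them describe weak inhibition at the concentration tested.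

Compound 4 `COc1cc2nc(NCCCN3CCCC3=O)nc(NC3CCCCCC3)c2cc1OC` is not yet measured. It differs from compound 1 in one place: 2-(2-oxopyrrolidin-1-yl)ethyl in place of phenyl on a saturated chain carbon bound to a nitrogen on an aromatic ring. Among the measured compounds shown here, no measured pair in this set shares this change, so nothing among the measured compounds can be read as a precedent for it. All three measured readings sit at the low end of the scale, and there is no indication from compound 1, compound 2 or compound 3 that a change in this part of the molecule moves the number far. The step expected in this assay is a number 1 percentage points lower from compound 1 to compound 4 (within the scatter), that is, nothing beyond the scatter. Compound 4 is therefore estimated to give 12%, with a range from 0% to 30%.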

Compound 4, a percentage reported as inhibition, at one concentration (the size of the read-out at that concentration, not a potency): 8%
For compound 4 the middle estimate is 4 percentage points above the measured one, and the stated range covers the measured number.
By their numbers in this assay, from the lowest: compounds 2, 4, 3 and 1 (each within the scatter of the next).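

Among the compounds shown here, replacing phenyl with 2-(2-oxopyrrolidin-1-yl)ethyl on a saturated chain carbon bound to a nitrogen on an aromatic ring gives, in this assay, a number 5 percentage points lower from compound 1 to compound 4 (within the scatter) and is the first comparison in this set between compounds that differ in one place. With the six-membered aromatic ring of carbon replaced here by a larger group with a five-membered non-aromatic ring and a carbonyl, the numbers of compound 1 and compound 4 in this assay are level within the scatter. No accompanying measurement bears on this result.

The compounds shown leave open whether any group at this place can raise the reading beyond the scatter, as this single change only links two readings that lie within the scatter of each other. A tertiary amine or a carboxylic acid at the end of the chain, or a substituted phenyl in place of the plain ring, would test this place further, and the benzylamino group of compound 1 is still not compared in one step with the groups carried by the other compounds.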